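Shifting the halobenzyl substituent toward a nitrobenzyl group

The compounds below may be only part of what the source reports. "The series", "measured", "known", "first", "only" and "open" are said of these compounds alone.

The three measured compounds share one core and differ only in the aryl group on the saturated chain carbon bound to a sulfur. Compound 1 `Brc1ccccc1CSc1nnc(-c2ccncc2)n1-c1ccccc1` carries a 2-bromophenyl there, and in a functional assay on HepG2 cells (Homo sapiens) for inhibition, read by MTT assay, with a stated time of 48 h (on this read-out lower numbers stand for stronger inhibition and higher numbers for weaker inhibition), compound 1 gives 17100 nM, the highest of the three numbers. Compound 2 `Brc1cccc(CSc2nnc(-c3ccncc3)n2-c2ccccc2)c1` gives 7040 nM and compound 3 `Brc1ccc(CSc2nnc(-c3ccncc3)n2-c2ccccc2)cc1` gives 12900 nM. The step of a 2.4-fold lower number from compound 1 to compound 2 (0.39 log units; beyond the scatter) is the only one beyond the scatter; the steps of a 1.3-fold lower number from compound 1 to compound 3 (0.12 log units; within the scatter) and a 1.8-fold higher number from compound 2 to compound 3 (0.26 log units; within the scatter) both stay within it.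

Compound 4 `O=[N+]([O-])c1ccc(CSc2nnc(-c3ccncc3)n2-c2ccccc2)cc1` is not yet measured. Its change from compound 1 is 4-nitrophenyl in place of 2-bromophenyl on a saturated chain carbon bound to a sulfur. Among the compounds with values here, two measured steps bear on it: moving the bromine from the 2-bromophenyl to the 4-bromophenyl, a 1.3-fold lower number from compound 1 to compound 3 (0.12 log units; within the scatter), changed little, while a 2.4-fold lower number from compound 1 to compound 2 (0.39 log units; beyond the scatter) was modest. Within the data shown here, no measured pair shows a nitro group replacing a bromine, so that part of the change is unsupported by data. He therefore expects at most a modest lowering, a 1.6-fold lower number from compound 1 to compound 4 (0.19 log units; within the scatter), which may well fall within the scatter. His estimate for compound 4 in this assay is 11000 nM, with a range from 4000 nM to 30000 nM.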

Compound 4, half-maximal inhibitory concentration: > 50000 nM
Compound 4: no number, only a limit; the forecaster's own chance of this, stated with the estimate: 10%; middle value at least 4.5-fold (0.65 log units) away from the limit.
By their numbers in this assay, from the lowest: compounds 2, 3 and 1 (each within the scatter of the next, the first and the last beyond it). At a limit, above all of these: compound 4.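

For compound 4, this assay gives only a limit and not a number: the limit of > 50000 nM in this assay, at which 1 of the 4 values shown sits.

Even so, the single change of nitro in place of bromo on an aromatic carbon is readable, as an at least 3.8-fold higher number from compound 3 to compound 4 (0.58 log units; beyond the scatter) shows that this place on the shared core does not tolerate every substituent equally. The steps of an at least 2.9-fold higher number from compound 1 to compound 4 (0.46 log units; beyond the scatter) and an at least 7.1-fold higher number from compound 2 to compound 4 (0.85 log units; beyond the scatter) point the same way, so all three bromophenyl compounds stand on the lower side of compound 4, and the earlier moves of the bromine alone had not shown that the identity of the group on the ring can matter here as well as its place.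

Going by these compounds, how far compound 4 lies beyond its limit stays unknown, and so does the true size of all three steps. Also open, on these data alone, is whether the nitro group would give the same result at the places the bromine holds in compound 1 and compound 2, and whether an amine or a carboxylic acid on the same ring would move the number in the same direction or the other way.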